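The compounds below may be only part of what the source reports. "The series", "measured", "known", "first", "only" and "open" are said of these compounds alone.

Working notes on the series, read in a functional assay on HeLa cells (Homo sapiens) for cytotoxicity, read by MTT assay; on this read-out higher numbers stand for weaker inhibition and lower numbers for stronger inhibition: compound 1 (`CC[C@](C)(O)CC(=O)O[C@H](CC=C(C)C)C1=CC(=O)c2c(O)ccc(O)c2C1=O`) gives 30200 nM and compound 2 (`CC(=O)OC(C)CO[C@H](CC=C(C)C)C1=CC(=O)c2c(O)ccc(O)c2C1=O`) gives 40100 nM, so compound 2 stands within the scatter of compound 1. Compound 3 (`CCC(C)(O)CC(=O)O[C@H](CC=C(C)C)C1=CC(=O)c2c(O)ccc(O)c2C1=O`) is reached from compound 2 by (2-hydroxy-2-methylbutyl)carbonyl in place of 2-acetoxypropyl on an oxygen on a saturated carbon. Among the compounds with values here, one measured step bears on this, the same swap in reverse: a 1.3-fold higher number from compound 1 to compound 2 (0.12 log units; within the scatter). Compound 1 carries the entering (2-hydroxy-2-methylbutyl)carbonyl. No change beyond the scatter is therefore expected in this assay, and the estimated step is a 1.3-fold lower number from compound 2 to compound 3 (0.11 log units; within the scatter). Compound 3 is expected at 31000 nM, with an estimated range of 18000 nM to 52000 nM.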

Compound 3, half-maximal inhibitory concentration: 25200 nM
For compound 3 the middle estimate is 1.2-fold (0.09 log units) above the measured one, within the range that was stated.
By their numbers in this assay, from the lowest: compounds 3, 1 and 2 (each within the scatter of the next).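

In this assay the swap on an oxygen on a saturated carbon now has a second reading, a 1.6-fold lower number from compound 2 to compound 3 (0.20 log units; within the scatter), so 2-acetoxypropyl and (2-hydroxy-2-methylbutyl)carbonyl are again not separated at this position. The stereocentre at a saturated chain carbon brings no separation either, with a 1.2-fold lower number from compound 1 to compound 3 (0.08 log units; within the scatter). That comparison gives only a limited reading of configuration: the fact that one of compounds 1 and 3 is drawn with a defined configuration and the other without, at the place where they differ

As far as these compounds go, whether an amine or a carboxylic acid on this oxygen would give a step beyond the scatter remains open. From the compounds shown here alone, how a compound drawn with the opposite configuration at that stereocentre would read also remains open.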